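The source may report more compounds than this note shows. Statements on the series, on what has been measured and on what is new or still open speak of the compounds shown alone.

Measured so far:
- Compound 1, `Cc1cccc(-c2cccc(OC(=O)NC3CCCCC3)c2)c1`, 61.8 nM
- Compound 2, `O=C(NC1CCCCC1)Oc1cccc(-c2cccc(-c3ccccc3)c2)c1`, 565 nM

Among the compounds with values here, in an assay on cell membranes for binding affinity to Fatty-acid amide hydrolase 1 (Rattus norvegicus) (a higher number here means a weaker inhibitor, a lower number a stronger inhibitor), compound 2 stands highest of the two numbers; its nearest neighbour is compound 1, and the one step that connects them, a 9.1-fold higher number from compound 1 to compound 2 (0.96 log units; beyond the scatter), lies beyond the scatter. Compound 3, `O=C(NC1CCCCC1)Oc1cccc(-c2cccc(Cc3ccccc3)c2)c1`, has not yet been measured. It differs from compound 2 by one change: benzyl in place of phenyl on an aromatic carbon. Within the data shown here, no measured step matches this change exactly. Among the measured compounds shown here, the only step that bears on it at all is the one from compound 1 to compound 2, where a phenyl replacing a methyl raised the number by a modest amount. A benzyl keeps a large aromatic group at the same place, so little movement is expected in this assay. Compound 3 is therefore estimated at 450 nM, with a range of 150 nM to 1400 nM, corresponding to an expected step of a 1.3-fold lower number from compound 2 to compound 3 (0.10 log units; within the scatter).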

Compound 3, half-maximal inhibitory concentration: 1860 nM
Estimate against measurement, compound 3: 4.1-fold (0.62 log units) below; measured number above the stated range.
By their numbers in this assay, from the lowest: compound 1; then compound 2; then compound 3.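

In this assay, the change from phenyl to benzyl gives a 3.3-fold higher number from compound 2 to compound 3 (0.52 log units; beyond the scatter), so keeping a six-membered aromatic ring of carbon only on this aromatic carbon does not hold the number steady, and the identity of the group still matters. Adding a phenyl in place of hydrogen on the methyl carbon gives a 30-fold higher number from compound 1 to compound 3 (1.48 log units; beyond the scatter), and across these three compounds the number rises in the order methyl, phenyl, benzyl, with no compound shown going against that order. No available evidence bears on the reason for this rise. On these data alone, whether the number would keep rising with a phenethyl chain at this place remains open. So does how an amine or a carboxylic acid on this aromatic carbon would read in this assay.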